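Chloro-to-methyl swap on the shared core, second instance

The source may report more compounds than this note shows. Statements on the series, on what has been measured and on what is new or still open speak of the compounds shown alone.

Compound 1 `Cc1cc(-c2nc3cc(Cl)ccc3o2)ccc1NC(=O)CN1CCN(CCCN(C)C)CC1` and compound 3 `Cc1ccc2oc(-c3ccc(NC(=O)CN4CCN(CCCN(C)C)CC4)c(C)c3)nc2c1` differ by methyl in place of chloro on an aromatic carbon. In a functional assay on A549 cells (Homo sapiens) for cytotoxicity, read by MTT assay, with a stated time of 24 h (a higher number here means a weaker inhibitor, a lower number a stronger inhibitor), compound 1 gives 10500 nM, and compound 3 gives 15300 nM; the step is a 1.5-fold higher number from compound 1 to compound 3 (0.16 log units; within the scatter). Compound 2 `Cc1cc(-c2nc3cc(Cl)ccc3o2)ccc1NC(=O)CCl` carries the same chloro-bearing core as compound 1 on a different amide, but how the two cores differ overall is not broken down here. In this assay compound 2 gives 91500 nM, the highest of the three numbers, with compound 3 its nearest neighbour and compound 1 the furthest, both gaps beyond the scatter. Compound 4 `Cc1ccc2oc(-c3ccc(NC(=O)CCl)c(C)c3)nc2c1` has not yet been measured; it differs from compound 2 by methyl in place of chloro on an aromatic carbon. The surroundings of the change read the same as from compound 1 to compound 3, so this is the same change. Compound 4 is expected to show a 1.3-fold higher number from compound 2 to compound 4 (0.10 log units; within the scatter), a step within the scatter like the earlier one, resting on that single prior instance. Compound 4 is estimated at 115000 nM, between 45000 nM and 300000 nM. Because compound 2 already gives 91500 nM, the highest of the three measured numbers, compound 4 is expected to sit at the weak end of this small set.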

Compound 4, half-maximal inhibitory concentration: 61800 nM
For compound 4 the middle estimate is 1.9-fold (0.27 log units) above the measured one; the measured number falls inside the stated range.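

In this assay methyl in place of chloro on an aromatic carbon gives a 1.5-fold lower number from compound 2 to compound 4 (0.17 log units; within the scatter) and so stays within the scatter on this second core. The two instances of the swap point in opposite printed directions, but the gap between them is also within the scatter, so they do not differ: the same change on two cores in this assay, a 1.5-fold higher number (0.16 log units; within the scatter) from compound 1 to compound 3 and a 1.5-fold lower number (0.17 log units; within the scatter) from compound 2 to compound 4, 2.2-fold (0.33 log units) apart, within the scatter of two such steps.

On the pairs shown, chloro and methyl at this place cannot be told apart on either core, but two pairs establish neither a direction for the change nor that it would carry to cores beyond these two.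

The compounds shown leave open whether a different group at this place, such as methoxy, nitrile or an amine, would move the number beyond the scatter. They also leave open whether the swap would remain this small with a longer chain or a carboxylic acid on the amide side, or in another cell line.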